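The source may hold more compounds than are shown below. What is called first, only, known or untested is meant among the compounds shown, and "the series" means these compounds.

Measured compounds:
- Compound 1, `CC(C)c1c(C(=O)N2CCC[C@H](c3ccccc3)C2)nn(-c2ccc(F)cc2)c1CC[C@@H](O)C[C@@H](O)CC(=O)O`: in an assay on microsomes from liver for inhibition of 3-hydroxy-3-methylglutaryl-coenzyme A reductase (Rattus norvegicus) (a lower number here means a stronger inhibitor, a higher number a weaker inhibitor), compound 1 gives 2.1 nM.
- Compound 2, `CC(C)c1c(C(=O)N(C)Cc2ccccc2)nn(-c2ccc(F)cc2)c1OC[C@@H](O)C[C@@H](O)CC(=O)O`: in this assay compound 2 gives 5.2 nM.
- Compound 3, `CC(C)c1c(C(=O)N2CCC[C@H](c3ccccc3)C2)nn(-c2ccc(F)cc2)c1OC[C@@H](O)C[C@@H](O)CC(=O)O`: in this assay compound 3 gives 4.8 nM.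

Among these three numbers compound 3 has the second highest. Its nearest neighbour is compound 2, whose number is within the scatter of that of compound 3, so the two cannot be told apart. The step of a 2.3-fold higher number from compound 1 to compound 3 (0.36 log units; beyond the scatter) is the only one beyond the scatter, and it concerns a change in the chain on the core, not the amide side.

Compound 4 is `CC(C)c1c(C(=O)N(C)Cc2cccc(F)c2)nn(-c2ccc(F)cc2)c1OC[C@@H](O)C[C@@H](O)CC(=O)O`. It differs from compound 3 by (3-fluorobenzyl)(methyl)amino in place of 3-phenylpiperidin-1-yl on a carbonyl carbon. The step that bears on this is a 1.1-fold lower number from compound 2 to compound 3 (0.03 log units; within the scatter), which swaps the same two kinds of amide group and lies within the scatter. Compound 4 adds only a fluorine to the benzyl group of compound 2, for which no measured comparison exists. The expectation is therefore a step of a 1.0-fold higher number from compound 3 to compound 4 (0.02 log units; within the scatter), that is, no change beyond the scatter. For compound 4 the estimated value in this assay is 5 nM, with a range from 2.5 nM to 10 nM.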

Compound 4, half-maximal inhibitory concentration: 14 nM
Estimate against measurement, compound 4: 2.8-fold (0.45 log units) below, and the stated range ends below it.
By their numbers in this assay, from the lowest: compound 1; then compounds 3 and 2 (each within the scatter of the next); then compound 4.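

Until now the amide side looked insensitive, since a 1.1-fold lower number from compound 2 to compound 3 (0.03 log units; within the scatter) showed that exchanging benzyl(methyl)amino for 3-phenylpiperidin-1-yl on the carbonyl carbon made no measurable difference in this assay. The new result shows that this part of the molecule does respond: fluoro in place of hydrogen on an aromatic carbon of the benzyl group gives a 2.7-fold higher number from compound 2 to compound 4 (0.43 log units; beyond the scatter), and exchanging 3-phenylpiperidin-1-yl for (3-fluorobenzyl)(methyl)amino gives a 2.9-fold higher number from compound 3 to compound 4 (0.46 log units; beyond the scatter), so the same kind of amide exchange can be silent or not, depending on the benzyl group that enters. Nothing available explains why a single fluorine shifts the number.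

With only one substituted benzyl group shown, it stays open whether the loss belongs to fluorine itself or would also appear with another group in its place, such as the 3-chlorobenzyl or 3-methoxybenzyl group. From the compounds shown here alone, it is also open whether the (3-fluorobenzyl)(methyl)amino amide would give a similar step on the 6-carboxy-3,5-dihydroxyhexyl chain of compound 1.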